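The compounds below may be only part of what the source reports. "The series", "measured", "known", "first", "only" and "open" are said of these compounds alone.

Measured compounds in hand:
- compound 1 `N[C@H]1CC[C@H](Nc2c(C(=O)NCc3ccc(F)cc3)nc(N3CCCCC3)c3cccnc23)CC1`: 5000 nM
- compound 2 `COc1cccc(CNC(=O)c2nc(Br)c3cccnc3c2N[C@H]2CC[C@H](N)CC2)c1`: 7000 nM
- compound 3 `CS(=O)(=O)NCCCN(c1nc(C(=O)NCc2ccc(F)cc2)c(O)c2ncccc12)S(C)(=O)=O`: > 20000 nM

In a functional assay on MDA-MB-435 cells (Homo sapiens) for cytotoxicity, read by MTT assay, with a stated time of 72 h (on this read-out lower numbers stand for stronger inhibition and higher numbers for weaker inhibition), compound 2 gives 7000 nM, the higher of the two numbers recorded. Its nearest neighbour is compound 1, which gives 5000 nM; the gap between compound 1 and compound 2 lies within the scatter, so no order between them can be read. For compound 3 the read-out is a limit and not a number. Compound 3 sits at the limit of > 20000 nM in this assay, at which 1 of the 3 values shown sits.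

Compound 4 `COC(=O)c1nc(Br)c2cccnc2c1N[C@H]1CC[C@H](N)CC1` is not yet measured. Compared with compound 2 it differs in one place: methoxy in place of (3-methoxybenzyl)amino on a carbonyl carbon. Methoxy in place of (3-methoxybenzyl)amino on a carbonyl carbon; the ring of carbon only and the hydrogen-bond donor counted on the leaving group are gone. Among the compounds with values here, no measured pair shows a change at this carbonyl carbon, so the direction rests on structure alone. Given that all three measured compounds keep an amide at this position, the step from compound 2 is expected to run upward, toward weaker inhibition, beyond the scatter; the expected step is a 2.9-fold higher number from compound 2 to compound 4 (0.46 log units; beyond the scatter). Compound 4 is expected to give about 20000 nM, between 7000 nM and 60000 nM, with a fair chance that this assay reports only a limit.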

Compound 4, half-maximal inhibitory concentration: > 20000 nM
Compound 4: only a limit was reported; the forecaster's own chance of this, stated with the estimate: 55%; the middle value sits exactly at the limit.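

In this assay, putting methoxy in place of (3-methoxybenzyl)amino on this carbonyl carbon gives an at least 2.8-fold higher number from compound 2 to compound 4 (0.45 log units; beyond the scatter), the first step read at this position, and it lies beyond the scatter. Compound 4 gives > 20000 nM, which is a limit and not a number, so the step has a floor but no measured size. Compound 4 shares this limit with compound 3, whose structure differs in more than one place: the limit of > 20000 nM in this assay, at which 2 of the 4 values shown sit.

The change removes the ring of carbon only and the hydrogen-bond donor together, so the compounds shown do not separate the two. Going by these compounds, whether a plain methylamino group or a carboxylic acid on this carbonyl carbon would read close to compound 2 at 7000 nM remains open.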